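This account rests on a few compounds, and the source may have more. Where it says the series, first, only, none or still open, it means among the compounds named here.

Measured compounds in a functional assay on PC-3 cells (Homo sapiens) for antiproliferative activity, read by MTT assay, with a stated time of 48 h; on this read-out lower numbers stand for stronger inhibition and higher numbers for weaker inhibition:
- compound 1 `CC1(C)Cc2c(ccc(C(=O)/C=C/c3cn(-c4ccccc4)nc3-c3cccc([N+](=O)[O-])c3)c2OCc2ccccc2)O1`, > 100000 nM
- compound 2 `COc1ccc(-c2nn(-c3ccccc3)cc2/C=C/C(=O)c2ccc(O)c3c2OC(C)(C)C3)cc1`, 20800 nM
- compound 3 `CC1(C)Cc2c(OCc3ccccc3)ccc(C(=O)/C=C/c3cn(-c4ccccc4)nc3-c3ccc([N+](=O)[O-])cc3)c2O1`, > 100000 nM

The value for compound 1 in this assay is a limit of the assay, not a number. The same holds for compound 3, whose value is also a limit. Of the three measured compounds only compound 2 gives a number, 20800 nM, so compound 1 cannot be placed relative to compound 2 beyond saying that compound 2 has a number where compound 1 has none. The limit is recorded in the limit of > 100000 nM in this assay, at which 2 of the 3 values shown sit.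

Compound 4 `COc1ccc(-c2nn(-c3ccccc3)cc2/C=C/C(=O)c2ccc3c(c2OCc2ccccc2)CC(C)(C)O3)cc1` is not yet measured. It differs from compound 1 in one place: 4-methoxyphenyl in place of 3-nitrophenyl on an aromatic carbon. Within the data shown here, no step between two measured compounds carries this same change, so its size is unknown here. Among the measured compounds shown here, compound 2, the only compound with a number, carries the 4-methoxyphenyl that enters here, but it also differs from compound 4 elsewhere in the core, and what its value shows beside the limits of compound 1 and compound 3 cannot be split between the two differences.

Compound 4 is expected to move only modestly, most likely a step of an at least 1.4-fold lower number from compound 1 to compound 4 (0.15 log units; that floor lies within the scatter) that may still leave it at the limit. Compound 4 is estimated at 70000 nM, with a range from 15000 nM to 300000 nM.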

Compound 4, half-maximal inhibitory concentration: 18400 nM
Estimate against measurement, compound 4: 3.8-fold (0.58 log units) above; low and high end bracket the measured number.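

In this assay, among these compounds, 4-methoxyphenyl in place of 3-nitrophenyl on this aromatic carbon of the five-membered ring gives the only readable step so far, an at least 5.4-fold lower number from compound 1 to compound 4 (0.73 log units; beyond the scatter), so the group at this position can move the read-out beyond the scatter while the rest of the structure stays the same. The core of compound 1 can therefore carry a measured number: compound 4 keeps that core and gives 18400 nM. The size of the step has only a lower bound because the value of compound 1 is a limit: the limit of > 100000 nM in this assay, at which 2 of the 4 values shown sit.

The compounds shown do not separate the loss of the nitro group from the gain of the methoxy group, and a plain phenyl or a 3-methoxyphenyl at this carbon would bear on that question. On these data alone, how far the read-out would follow other groups on this phenyl ring, such as a dimethylamino group or a carboxylic acid, also stays open, and steps involving compound 3 cannot be read.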